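A Methyl Analogue in a Series Without Measurable Toxicity

The compounds below may be only part of what the source reports. "The series", "measured", "known", "first", "only" and "open" are said of these compounds alone.

Compound 1 `O=c1ccn(COC(CO)CO)c(=O)[nH]1` gives > 462000 nM in a functional assay on Vero cells (Chlorocebus sabaeus) for cytotoxicity (on this read-out lower numbers stand for higher toxicity in this test and higher numbers for lower toxicity in this test), which is a limit.
Compound 2 `Nc1cn(COC(CO)CO)c(=O)[nH]c1=O` gives > 432000 nM in this assay, which is a limit.
Compound 3 `O=c1[nH]c(=O)n(COC(CO)CO)cc1CCO` gives > 384000 nM in this assay, which is a limit.

Every value here is a limit of the assay rather than a number. Compound 1 has no fixed position among the three. The steps a step that the two limits leave unreadable from compound 1 to compound 2 and a step that the two limits leave unreadable from compound 1 to compound 3 cannot be read in size, and the same holds for a step that the two limits leave unreadable from compound 2 to compound 3. Compound 4 `Cc1cc(=O)[nH]c(=O)n1COC(CO)CO` differs from compound 1 by methyl in place of hydrogen on an aromatic carbon. The measured steps bear on this change only in that each change on the shared core left the value at a limit (the limit of > 384000 nM in this assay, at which 1 of the 3 values shown sits, (the limit of > 432000 nM in this assay, at which 1 of the 3 values shown sits), (the limit of > 462000 nM in this assay, at which 1 of the 3 values shown sits)). In this assay no step beyond the scatter is expected, and the step that the limit leaves unreadable from compound 1 to compound 4 is an estimate that the measurement will most likely end as a limit again. Compound 4 is expected to give 480000 nM, between 250000 nM and 1000000 nM.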

Compound 4, half-maximal cytotoxic concentration: > 434000 nM
Compound 4 was reported as a limit (the forecaster's own chance of this, stated with the estimate: 90%); the middle value lies beyond the limit too.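

Compound 4, like compound 1, is reported only as a limit, so the step between them cannot be read. Whether any of the compounds shown would give an actual number in this assay remains open.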